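Lengthening the imidazole tether on the imide scaffold

A few compounds are considered here, and "the series" means these few. Any claim that something is new, unique, unknown or untested is made for them only; others in the source may bear on it.

In a functional assay on ECa-109 cells (Homo sapiens) for antiproliferative activity, read by MTT assay, with a stated time of 48 h (on this read-out higher numbers stand for weaker inhibition and lower numbers for stronger inhibition), compound 1 `Cn1cc(C2=C(c3nn(CCn4ccnc4)c4ncccc34)C(=O)NC2=O)c2ccccc21` reaches only the limit of the assay, > 100000 nM, and so gives no number of its own. This places compound 1 at the limit of > 100000 nM in this assay, at which 2 of the 3 values shown sit. Compound 2 `Cn1cc(C2=C(c3n[nH]c4ncccc34)C(=O)N(c3cccc4ccccc34)C2=O)c2ccccc21` likewise returns only the limit, > 100000 nM, in this assay. Among the measured compounds shown here, compound 3 `Cn1cc(C2=C(c3nn(CCCN4CCCCC4)c4ncccc34)C(=O)N(c3ccccn3)C2=O)c2ccccc21`, the single member of the set with a numerical value, gives 7300 nM in this assay. For the measured compounds named here, no step between two measured compounds that differ in a single place is available here, so the pair of limits and the one number are all that can be read.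

Compound 4 `Cn1cc(C2=C(c3nn(CCCn4ccnc4)c4ncccc34)C(=O)NC2=O)c2ccccc21` differs from compound 1 by (1H-imidazol-1-yl)methyl in place of 1H-imidazol-1-yl on a saturated chain carbon, two bonds along the chain from an aromatic nitrogen, that is, by a single additional chain carbon between the aromatic nitrogen and the imidazole. Because compound 1 sits at > 100000 nM, a limit, compound 4 is expected to stay at or near that limit, with the step that the limit leaves unreadable from compound 1 to compound 4 expected to be no more than the usual scatter, in no clear direction. Compound 4 is therefore estimated at 150000 nM, within a range of 30000 nM to 600000 nM, most probably reported again as a limit.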

Compound 4, half-maximal inhibitory concentration: > 100000 nM
Compound 4: only a limit was reported; the forecaster's own chance of this, stated with the estimate: 70%; the middle value does not contradict the limit.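

In this assay compound 4 gives > 100000 nM, a limit of the assay and not a number. Compound 1 also stands at a limit, so no step between the two can be read: the limit of > 100000 nM in this assay, at which 3 of the 4 values shown sit.

The compounds shown leave open whether the added chain carbon changes antiproliferative activity at all.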